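The source may hold more compounds than are shown below. What is called first, only, known or untested is meant among the compounds shown, and "the series" means these compounds.

Compound 1 `CC(C)NCCOc1c(O)cc(O)c2c(=O)cc(-c3ccccc3)oc12` is recorded in a functional assay on A549 cells (Homo sapiens) for cytotoxicity, read by MTT assay, with a stated time of 48 h (a lower number here means a stronger inhibitor, a higher number a weaker inhibitor), as "not determined" (no result reported), with no number reported. For the measured compounds named here, compound 2 `COc1c(OCCCN2CCN(C)CC2)cc(O)c2c(=O)cc(-c3ccccc3)oc12` is the only compound with a number in this assay; in this assay compound 2 gives 9900 nM and so stands alone as the reference point. Compound 3 `COc1c(OCCCN2CCCC2)cc(O)c2c(=O)cc(-c3ccccc3)oc12` has not yet been measured. It differs from compound 2 in one place: pyrrolidin-1-yl in place of 4-methylpiperazin-1-yl on a saturated chain carbon, three bonds along the chain from an oxygen on an aromatic ring. Going by the values given here, with no measured step available to lean on, the shift expected in this assay is small, likely within the usual scatter: a 1.1-fold lower number from compound 2 to compound 3 (0.04 log units; within the scatter). Compound 3 is therefore estimated at 9000 nM, with a plausible range from 3500 nM to 25000 nM.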

Compound 3, half-maximal inhibitory concentration: 1390 nM
Beside the measured number, compound 3's estimate is 6.5-fold (0.81 log units) above it; the whole stated range lies above it.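

In this assay, the group at the end of the side chain clearly matters: pyrrolidin-1-yl in place of 4-methylpiperazin-1-yl gives a 7.1-fold lower number from compound 2 to compound 3 (0.85 log units; beyond the scatter). The shared core and the chain stay the same, so this one exchange goes with the whole difference. No measured evidence explains the lower number.

This single step cannot separate ring size from the loss of the second ring nitrogen. Piperidin-1-yl, a six-membered ring with one nitrogen, would address that question, while a 2-(pyrrolidin-1-yl)ethyl chain would test the chain length.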